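A few compounds are considered here, and "the series" means these few. Any claim that something is new, unique, unknown or untested is made for them only; others in the source may bear on it.

Compound 2 `CCOC(=O)c1c(C)[nH]c(=O)c(C#N)c1-c1ccc(F)cc1` is measured in a functional assay on HepG2 cells (Homo sapiens) for inhibition, read by MTT assay, with a stated time of 24 h (on this read-out lower numbers stand for stronger inhibition and higher numbers for weaker inhibition), where compound 2 gives 18600 nM. For the measured compounds named here, its only measured neighbour is compound 1 `CCOC(=O)c1c(C)[nH]c(=O)c(C#N)c1-c1ccc(C#N)cc1`, which in this assay gives 20200 nM; the two numbers sit within the scatter of each other, so the two compounds cannot be told apart on this read-out. Compound 3 `CCOC(=O)c1c(C)[nH]c(=O)c(C#N)c1-c1ccc(Br)cc1` has not yet been measured. It differs from compound 2 by bromo in place of fluoro on an aromatic carbon. Going by the values given here, the one measured step that bears on this change is a 1.1-fold lower number from compound 1 to compound 2 (0.04 log units; within the scatter), a swap at the same place that left the number essentially where it was. On that basis no step beyond the scatter is expected in this assay for compound 3, in either direction. Compound 3 is therefore estimated at 17000 nM, with a range from 7000 nM to 45000 nM, which amounts to an expected step of a 1.1-fold lower number from compound 2 to compound 3 (0.04 log units; within the scatter).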

Compound 3, half-maximal inhibitory concentration: 65500 nM
Compound 3: middle estimate off by 3.9-fold (0.59 log units), on the low side; the measured number lies above the stated range.
By their numbers in this assay, from the lowest: compounds 2 and 1 (each within the scatter of the next); then compound 3.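

In this assay the change from 4-fluorophenyl to 4-bromophenyl gives a 3.5-fold higher number from compound 2 to compound 3 (0.55 log units; beyond the scatter) and bromo in place of cyano gives a 3.2-fold higher number from compound 1 to compound 3 (0.51 log units; beyond the scatter) so this position, which seemed indifferent when only fluoro and cyano could be compared, does respond to the group it carries. Among these three compounds, bromo alone shifts the number, towards weaker inhibition, while fluoro and cyano remain within the scatter of each other. No measurement at hand accounts for why bromo parts from the other two groups.

The compounds shown leave open whether chloro or iodo at this place would follow bromo or stay with fluoro, and how an amine or a carboxylic acid would fare there. They also leave open whether the bromo step would persist if the ethyl ester were replaced.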